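Pyridin-3-yl for 3-chlorophenyl on the arm

The source may hold more compounds than are shown below. What is called first, only, known or untested is meant among the compounds shown, and "the series" means these compounds.

Working notes on the series. Compound 1 `COc1cccc(Cc2cc(-c3ccc(C)cc3)nn(CC(=O)Nc3ccc(F)cc3)c2=O)c1` and compound 2 `Cc1cc(Cc2cccc(Cl)c2)c(=O)n(CC(=O)Nc2ccc(Br)cc2)n1` share a common core. In an assay on HL-60 cells for agonist activity at N-formyl peptide receptor 3 (Homo sapiens), read by calcium flux (a lower number here means that less compound is needed, a higher number that more compound is needed for the effect), compound 1 returns only a limit of the assay, > 50000 nM. Compound 2 likewise gives only a limit of the assay in this assay, > 50000 nM. Among the measured compounds shown here, both values sit at the same limit (the limit of > 50000 nM in this assay, at which 2 of the 2 values shown sit), so compound 2 cannot be placed relative to compound 1, and no measured step between them exists. Compound 3 `Cc1cc(Cc2cccnc2)c(=O)n(CC(=O)Nc2ccc(Br)cc2)n1` is the next member: pyridin-3-yl in place of 3-chlorophenyl on a saturated chain carbon bound to an aromatic carbon. For the measured compounds named here, no measured pair in the set calibrates this change, so the expected step that the limit leaves unreadable from compound 2 to compound 3 in this assay is none beyond the scatter, with another limit the most probable outcome. Compound 3 is accordingly expected near 60000 nM, within 15000 nM to 250000 nM.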

Compound 3, half-maximal effective concentration: > 50000 nM
Compound 3 ended at the assay's limit; the forecaster's own chance of this, stated with the estimate: 85%; the middle value does not contradict the limit.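

In this assay compound 3 returns only a limit of the assay, > 50000 nM, so the step between compound 2 and compound 3 cannot be read: the limit of > 50000 nM in this assay, at which 3 of the 3 values shown sit.

The compounds shown leave open whether any member of the series gives a measurable value in this assay, and how pyridin-3-yl compares with 3-chlorophenyl.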